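A few compounds are considered here, and "the series" means these few. Any claim that something is new, unique, unknown or untested is made for them only; others in the source may bear on it.

In a functional assay on SH-SY5Y cells (Homo sapiens) for cytotoxicity, read by MTT assay, with stated times of 8 h, 30 min and 12 h, tested at 5 uM (a higher number here means a stronger effect of the compound at the concentration tested, a lower number a weaker effect), three compounds have been measured:

Compound 1 `N=C(NCc1ccccc1)[C@@H]1CCC(=O)N1Cc1ccccc1[N+](=O)[O-]` gives 25.3%.
Compound 2 `N=C(NCc1ccc(O)cc1)[C@@H]1CCC(=O)N1Cc1ccccc1[N+](=O)[O-]` gives 30.4%.
Compound 3 `N=C(NCc1ccccc1)[C@@H]1CCC(=O)N1Cc1ccc(F)cc1` gives 31.4%.

From compound 1 to compound 2 the change is hydroxy in place of hydrogen on an aromatic carbon, and this made a number 5.1 percentage points higher from compound 1 to compound 2 (within the scatter). Compound 3 has a different core from compound 1; how the two cores differ is not broken down here. Compound 4 `N=C(NCc1ccc(O)cc1)[C@@H]1CCC(=O)N1Cc1ccc(F)cc1` has not yet been measured. It differs from compound 3 by hydroxy in place of hydrogen on an aromatic carbon, the same change as from compound 1 to compound 2, at the same kind of place. Because the earlier step was a number 5.1 percentage points higher from compound 1 to compound 2 (within the scatter), the expected step from compound 3 to compound 4 in this assay is also small, estimated as a number 3.6 percentage points higher from compound 3 to compound 4 (within the scatter), lying within the scatter. On that basis compound 4 is expected to give about 35%, most likely between 22% and 48%.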

Compound 4, a percentage reported as activity, at one concentration (the size of the read-out at that concentration, not a potency): 48.6%
Estimate against measurement, compound 4: 13.6 percentage points below; the whole stated range lies below it.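

In this assay, the hydroxy change gives a number 17.2 percentage points higher from compound 3 to compound 4 (beyond the scatter), and 4-fluorophenyl in place of 2-nitrophenyl, with the hydroxy present, gives a number 18.2 percentage points higher from compound 2 to compound 4 (beyond the scatter). Set side by side, the hydroxy step on the two cores does not clearly differ: the same change on two cores in this assay, a number 5.1 percentage points higher (within the scatter) from compound 1 to compound 2 and a number 17.2 percentage points higher (beyond the scatter) from compound 3 to compound 4, 12.1 percentage points apart, within the scatter of two such steps. These two pairs therefore fit a change that carries from one core to the other, but they do not settle whether its size is the same on both.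

The compounds shown leave open whether another group in place of the hydroxy, such as an amine or a carboxylic acid, would give a similar step. They also leave open whether the hydroxy step would hold on cores other than these two.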